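The source may hold more compounds than are shown below. What is called first, only, known or untested is meant among the compounds shown, and "the series" means these compounds.

Compound 1 `COc1cc(N2C(N)=C(C#N)C(c3c(OC)ccc4ccccc34)C3=C2CC(C)(C)CC3=O)cc(OC)c1OC` — in a functional assay on Ehrlich cells (Mus musculus) for cytotoxicity, tested at 25 ug/mL (on this read-out lower numbers stand for a weaker effect and higher numbers for a stronger effect at the one concentration tested), compound 1 gives 5%.
Compound 2 `COc1cc(N2C(N)=C(C#N)C(c3c(O)ccc4ccccc34)C3=C2CC(C)(C)CC3=O)cc(OC)c1OC` — in this assay compound 2 gives 10%.
Compound 3 `COc1cc(N2C(N)=C(C#N)C(c3ccc(C)cc3)C3=C2CC(C)(C)CC3=O)cc(OC)c1OC` — in this assay compound 3 gives 50%.

Compound 3 stands highest of the three, and its steps to the others lie beyond the scatter: a number 45 percentage points higher from compound 1 to compound 3 (beyond the scatter) and a number 40 percentage points higher from compound 2 to compound 3 (beyond the scatter). Compound 4 `COc1cc(N2C(N)=C(C#N)C(c3ccc(C)o3)C3=C2CC(C)(C)CC3=O)cc(OC)c1OC` differs from compound 3 at the same saturated ring carbon: 5-methylfuran-2-yl in place of 4-methylphenyl on a saturated ring carbon. The two measured steps that changed this group were both large, so this position clearly matters; neither tested a five-membered aromatic ring with one hetero atom, so the direction is uncertain. A step down of moderate size is expected, a number 20 percentage points lower from compound 3 to compound 4 (beyond the scatter). Compound 4 is estimated at 30%, between 5% and 60%.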

Compound 4, a percentage reported as activity, at one concentration (the size of the read-out at that concentration, not a potency): 31%
Beside the measured number, compound 4's estimate is 1 percentage points below it; the range from low to high includes it.
By their numbers in this assay, from the lowest: compounds 1 and 2 (each within the scatter of the next); then compound 4; then compound 3.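

In this assay, 5-methylfuran-2-yl in place of 4-methylphenyl costs part of the effect but not all of it, with a number 19 percentage points lower from compound 3 to compound 4 (beyond the scatter). The furan compound still stands clear of both naphthalene compounds, with a number 21 percentage points higher from compound 2 to compound 4 (beyond the scatter) and a number 26 percentage points higher from compound 1 to compound 4 (beyond the scatter), so this saturated ring carbon gives graded results rather than an all-or-nothing switch, and a five-membered aromatic ring is tolerated here. Nothing available explains why these groups rank this way.

Still open, on these data alone, is what the methyl group on either ring contributes. Also open, as far as these compounds go, is how thiophen-2-yl, with sulfur in place of the furan oxygen, or a 4-aminophenyl group would compare.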